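Extending the saturated ring on the hydrazide chain

A few compounds are considered here, and "the series" means these few. Any claim that something is new, unique, unknown or untested is made for them only; others in the source may bear on it.

Among the compounds with values here, compound 3 `O=C(CCC1CCCC1)NNc1c(Cl)cncc1Cl` has the lowest number of the three compounds measured so far in a functional assay on HEK293 cells for antagonist activity at P2X purinoceptor 7 (Homo sapiens), read by fluorescence, with a stated time of 2 h (a higher number here means a weaker inhibitor, a lower number a stronger inhibitor), giving 380 nM. Compound 1 `O=C(CCc1ccc(Cl)cc1)NNc1c(Cl)cncc1Cl` gives 1100 nM in this assay and compound 2 `Cc1ccc(CCC(=O)NNc2c(Cl)cncc2Cl)cc1` gives 1400 nM; the step of a 2.9-fold lower number from compound 1 to compound 3 (0.46 log units; beyond the scatter) and the step of a 3.7-fold lower number from compound 2 to compound 3 (0.57 log units; beyond the scatter) both favour the saturated ring over the aromatic ring at this position. The step of a 1.3-fold higher number from compound 1 to compound 2 (0.10 log units; within the scatter) is within the scatter.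

Compound 4 `O=C(CCCC1CCCCC1)NNc1c(Cl)cncc1Cl` carries cyclohexylmethyl in place of cyclopentyl on a saturated chain carbon, two bonds along the chain from a carbonyl carbon. Within the data shown here, no measured step replaces one saturated ring with another, so the steps from compound 1 and compound 2 to compound 3 bear only indirectly: they show the saturated ring is tolerated at this place, not what a larger one with an extra chain carbon does. Compound 4 is therefore expected to stay near compound 3, with the step of a 1.2-fold lower number from compound 3 to compound 4 (0.07 log units; within the scatter) expected to lie within the scatter. Compound 4 is estimated at 320 nM, with a range from 110 nM to 1000 nM.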

Compound 4, half-maximal inhibitory concentration: 360 nM
Compound 4: the middle estimate sits 1.1-fold (0.05 log units) below what was measured, within the range that was stated.
By their numbers in this assay, from the lowest: compounds 4 and 3 (each within the scatter of the next); then compounds 1 and 2 (each within the scatter of the next).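

In this assay, cyclohexylmethyl in place of cyclopentyl on this saturated chain carbon gives no separable difference (a 1.1-fold lower number from compound 3 to compound 4 (0.02 log units; within the scatter)), so this position accepts both of these saturated groups at a similar level. The advantage over the aromatic groups also extends to a second saturated ring with an extra chain carbon (a 3.1-fold lower number from compound 1 to compound 4 (0.49 log units; beyond the scatter); a 3.9-fold lower number from compound 2 to compound 4 (0.59 log units; beyond the scatter)), and none of the four compounds goes against this pattern. No measurement given here accounts for this result.

Because the ring and the chain length differ together between compound 3 and compound 4, their separate contributions remain unresolved. Also open, on these data alone, is how this position would respond to a longer chain, or to a saturated ring carrying an amine or a carboxylic acid.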